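Swapping the aryl group on a thiourea: expectation for compound 3

The compounds below may be only part of what the source reports. "The series", "measured", "known", "first", "only" and "open" are said of these compounds alone.

Measured so far:
- compound 1 `COc1ccccc1NC(=S)NC1CC(C)(C)Oc2ccc(Br)cc21`: "not determined" (no result reported) in a functional assay on B16-F10 cells (Mus musculus) for inhibition, read by MTT assay, with a stated time of 72 h; a lower number here means a stronger inhibitor, a higher number a weaker inhibitor
- compound 2 `CC1(C)CC(NC(=S)Nc2cccc(C#N)c2)c2cc(F)ccc2O1`: 35000 nM

Compound 1 carries a 2-methoxyphenyl on the thiourea nitrogen. In this assay compound 1 gives "not determined" (no result reported), so it stands nowhere on the scale; compound 2, which shares the thiourea and the core, gives 35000 nM in this assay, a weak result.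

Compound 3 `CC1(C)CC(NC(=S)Nc2ccc(Cl)cc2)c2cc(Br)ccc2O1` is the untested partner of compound 1. The difference is 4-chlorophenyl in place of 2-methoxyphenyl on an amide-type nitrogen. For the measured compounds named here, with no value for compound 1, no step between compound 1 and compound 3 can be given, so nothing can be said about its size or direction beyond the scatter.

Because compound 2 gives 35000 nM in this assay, compound 3 is expected to land near it, at an estimated 30000 nM with a likely range from 8000 nM to 100000 nM.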

Compound 3, half-maximal inhibitory concentration: 7000 nM
Compound 3: middle estimate off by 4.3-fold (0.63 log units), on the high side; the whole stated range lies above it.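

For the compounds shown here, compound 1 has no number on this scale, so no step between compound 1 and compound 3 can be read. From the compounds shown here alone, what replacing 2-methoxyphenyl with 4-chlorophenyl does to inhibition stays open. No supporting evidence bears on the result for compound 3.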